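Group on the sulfur: compound 2 to compound 3

The source may report more compounds than this note shows. Statements on the series, on what has been measured and on what is new or still open speak of the compounds shown alone.

Measured so far in a functional assay on A549 cells (Homo sapiens) for inhibition, read by CCK-8 assay, with a stated time of 72 h, tested at 2 uM (on this read-out higher numbers stand for more inhibition of growth at the one concentration tested and lower numbers for less inhibition of growth), for this series
- compound 1 `COc1ccc(SCc2ccc(/C=C/C(=O)Nc3ccccc3N)cc2)cc1OC` gives 65.5%
- compound 2 `Nc1ccccc1NC(=O)/C=C/c1ccc(CSc2ccc(F)cc2)cc1` gives 51.2%

Within the data shown here, of the two numbers in this assay, compound 2 holds the lower, at 51.2%, and its only neighbour is compound 1 at 65.5% on the higher side.

Compound 3 `Nc1ccccc1NC(=O)/C=C/c1ccc(CSc2cccc3ccccc23)cc1` has not been measured. It carries naphthalen-1-yl in place of 4-fluorophenyl on a sulfur, and the rest of compound 2 is kept.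

Among the measured compounds shown here, the one measured step at this same place is a number 14.3 percentage points lower from compound 1 to compound 2 (beyond the scatter) and it is modest. For the measured compounds named here, it shows that the group on the sulfur can move the number, but no measured compound carries naphthalen-1-yl, so it gives only a rough scale and little guidance on direction.

A small step of a number 3.8 percentage points higher from compound 2 to compound 3 (within the scatter) is therefore expected in this assay, and its upward direction is held only weakly. For compound 3 the estimated value is 55% (expected range 38% to 72%).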

Compound 3, percent growth inhibition at one concentration: 59.3%
The estimate for compound 3 lay 4.3 percentage points below the measured number; the measured number falls inside the stated range.
By their numbers in this assay, from the lowest: compounds 2, 3 and 1 (each within the scatter of the next, the first and the last beyond it).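

In this assay, the step to naphthalen-1-yl reads as a number 8.1 percentage points higher from compound 2 to compound 3 (within the scatter), and the comparison with the dimethoxy compound reads as a number 6.2 percentage points lower from compound 1 to compound 3 (within the scatter), so compound 3 cannot be separated from either neighbour, even though a number 14.3 percentage points lower from compound 1 to compound 2 (beyond the scatter) separates those two from each other. Among these compounds, the place on the sulfur therefore accepts a larger group of 2 six-membered aromatic rings of carbon only, and 3,4-dimethoxyphenyl is not the only group there that gives a number within the scatter of compound 1. With three aromatic groups and one clear step among them, no ranking by group size or substitution can be drawn, and no measurement is available to explain any of these numbers.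

From the compounds shown here alone, whether the sulfur tolerates a group outside this aromatic set, such as a saturated cyclohexyl ring or a phenyl ring carrying a carboxylic acid or an aminomethyl group, remains open. Also open, going by these compounds, is whether the numbers in this assay, taken at one concentration, would keep the same relation across a full concentration range.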